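Methyl for chloro on the aryl group of compound 2

This account rests on a few compounds, and the source may have more. Where it says the series, first, only, none or still open, it means among the compounds named here.

Measured so far in a functional assay on CAKI-1 cells (Homo sapiens) for antiproliferative activity; on this read-out higher numbers stand for weaker inhibition of growth and lower numbers for stronger inhibition of growth
- compound 1 `Cc1ccnc2nc(-c3cccc(Cl)c3)cc(O)c12` gives 33.1 nM
- compound 2 `Cc1ccc2c(O)cc(-c3cccc(Cl)c3)nc2n1` gives 41.7 nM

Compound 2 stands within the scatter of compound 1, so the two numbers set no order. Compound 3 `Cc1cccc(-c2cc(O)c3ccc(C)nc3n2)c1` has methyl in place of chloro on an aromatic carbon of compound 2. Going by the values given here, no measured pair shows this exchange, so the expectation rests on compound 2 alone. A small move toward weaker inhibition of growth is expected, perhaps no larger than the scatter, and the estimated step is a 1.4-fold higher number from compound 2 to compound 3 (0.16 log units; within the scatter) in this assay on this basis. Compound 3 is expected at 60 nM (estimated range 25 nM to 150 nM).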

Compound 3, concentration for 50% growth inhibition: 427 nM
For compound 3 the middle estimate is 7.1-fold (0.85 log units) below the measured one; the measured number lies above the stated range.
By their numbers in this assay, from the lowest: compounds 1 and 2 (each within the scatter of the next); then compound 3.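

In this assay methyl in place of chloro on this aromatic carbon, meta to a large group, gives a 10-fold higher number from compound 2 to compound 3 (1.01 log units; beyond the scatter) and so the position clearly separates the two groups. Chloro and methyl each count one heavy atom and neither carries a hydrogen-bond donor or acceptor, so these counts do not account for the gap. Nothing on hand bears on the cause of this step. On these data alone, whether fluoro, methoxy or an amine at this position stays close to compound 2 remains open, as does whether the same exchange on compound 1 gives a step of similar size.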